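The source may report more compounds than this note shows. Statements on the series, on what has been measured and on what is new or still open speak of the compounds shown alone.

Measured so far:
Compound 1 `Cc1cn([C@@H]2O[C@@H]3COP(=O)(O)O[C@H]3[C@H]2O)c(=O)nc1N` — > 200 ug/mL
Compound 2 `CCCCCc1cn([C@@H]2O[C@@H]3CO[PH](O)(O)O[C@H]3[C@H]2O)c(=O)nc1N` — > 200 ug/mL
Compound 3 `CCCCCCc1cn([C@@H]2O[C@@H]3COP(=O)(O)O[C@H]3[C@H]2O)c(=O)nc1N` — > 200 ug/mL

In a functional assay on L1210 cells (Mus musculus) for cytotoxicity (on this read-out lower numbers stand for stronger inhibition and higher numbers for weaker inhibition), compound 3 gives > 200 ug/mL, which is a limit of the assay rather than a number. Compound 1 and compound 2 also sit at this limit, as the limit of > 200 ug/mL in this assay, at which 3 of the 3 values shown sit, shows. Within the data shown here, the only single-point comparison among them, a step that the two limits leave unreadable from compound 1 to compound 3, is unreadable because both ends are limits. Compound 4 `CCCCc1cn([C@@H]2O[C@@H]3COP(=O)(O)O[C@H]3[C@H]2O)c(=O)nc1N` differs from compound 3 by hydrogen in place of ethyl on a saturated chain carbon, four bonds along the chain from an aromatic carbon. Among the measured compounds shown here, no measured step reads a size here, and the shorter chain of compound 1 also sits at the limit, so no movement beyond the scatter is expected. Compound 4 is therefore expected near 300 ug/mL, within 100 ug/mL to 1000 ug/mL. The expected step is a step that the limit leaves unreadable from compound 3 to compound 4, most likely reported again as a limit.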

Compound 4, concentration for 50% inhibition: > 200 ug/mL
Compound 4: no number, only a limit; the forecaster's own chance of this, stated with the estimate: 85%; the middle value does not contradict the limit.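

The steps from compound 3 to compound 4 and from compound 1 to compound 4 cannot be read, because each of these compounds gives only a limit: the limit of > 200 ug/mL in this assay, at which 4 of the 4 values shown sit.

The compounds shown leave open how far apart they truly lie in this assay.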